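Chalcone series: chloro for fluoro on the styryl ring

The compounds below may be only part of what the source reports. "The series", "measured", "known", "first", "only" and "open" are said of these compounds alone.

Compound 1 `O=C(/C=C/c1ccc(F)cc1)c1ccc(OCc2ccccc2)cc1` and compound 2 `Cc1ccc(COc2ccc(C(=O)/C=C/c3ccc(F)cc3)cc2)cc1` share a benzyloxy-type side chain, and in a functional assay on HCT-116 cells (Homo sapiens) for antiproliferative activity, read by sulforhodamine B assay, with a stated time of 3 days, tested at 25 uM (on this read-out lower numbers stand for a weaker effect and higher numbers for a stronger effect at the one concentration tested), compound 1 gives "not determined" (no result reported) while compound 2 gives "not determined" (no result reported); so compound 1 stands with no single number, and one further entry is in the same position. Compound 3 `O=C(/C=C/c1ccc(F)cc1)c1ccccc1` carries no such side chain, and in this assay compound 3 gives 86.8%. Compound 4 `O=C(/C=C/c1ccc(Cl)cc1)c1ccc(OCc2ccccc2)cc1` differs from compound 1 by chloro in place of fluoro on an aromatic carbon. For the measured compounds named here, no measured step of this kind is recorded, and with no number for compound 1 the direction cannot be set; a change of no more than the scatter is expected. On this basis compound 4 is estimated at 75%, within 40% to 95%, leaning on compound 3 at 86.8%.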

Compound 4, a percentage reported as inhibition, at one concentration (the size of the read-out at that concentration, not a potency): 0.3%
Beside the measured number, compound 4's estimate is 74.7 percentage points above it; measured number below the stated range.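

No step can be read between compound 1 and compound 4, as compound 1 has no single number in this assay here. The compounds shown leave open what the 4-fluorophenyl to 4-chlorophenyl change does to this read-out. No evidence at hand bears on the result of compound 4.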